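The source may hold more compounds than are shown below. What is called first, only, known or untested is meant among the compounds shown, and "the series" means these compounds.

The study concerns a shared core carried by compound 1 `Cc1ccc(S(=O)(=O)Nc2ccc3c(c2)C(=O)N(Cc2ccccc2)C3=O)cc1` and compound 2 `O=C1c2ccc([N+](=O)[O-])cc2C(=O)N1CCNc1ccccc1`. In an assay on isolated protein for inhibition of lysosomal alpha-glucosidase (Rattus norvegicus), read by colorimetric assay (a lower number here means a stronger inhibitor, a higher number a weaker inhibitor), compound 1 gives only a limit, > 200000 nM, and no number. Compound 1 therefore stands at the limit of > 200000 nM in this assay, at which 1 of the 2 values shown sits. In this assay compound 2 gives 111000 nM, a weak inhibitor with a measured number. Compound 3 `Cc1ccc(S(=O)(=O)Nc2ccc3c(c2)C(=O)N(CCNc2ccccc2)C3=O)cc1` has not yet been tested; it differs from compound 1 by anilinomethyl in place of phenyl on a saturated chain carbon bound to an amide-type nitrogen in a ring. Going by the values given here, no step between measured compounds is available, and compound 2 differs from compound 3 elsewhere on the core, so what its value shows is only that a compound bearing the 2-anilinoethyl chain can fall inside the measurable range of this assay. A small step toward stronger inhibition is expected in this assay for compound 3, not clearly beyond the scatter. Compound 3 is estimated at 150000 nM, between 40000 nM and 500000 nM. The expected step is an at least 1.3-fold lower number from compound 1 to compound 3 (0.12 log units; that floor lies within the scatter).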

Compound 3, half-maximal inhibitory concentration: 99600 nM
The estimate for compound 3 lay 1.5-fold (0.18 log units) above the measured number, and the stated range covers the measured number.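

With anilinomethyl in place of phenyl on a saturated chain carbon bound to an amide-type nitrogen in a ring, the core of compound 1 now gives a measured number in this assay, as compound 3 stands at 99600 nM. On these data alone, the change is an at least 2.0-fold lower number from compound 1 to compound 3 (0.30 log units; that floor lies within the scatter), so its true size stays open and it cannot be said to exceed the scatter. Compound 1 gives a limit and no number: the limit of > 200000 nM in this assay, at which 1 of the 3 values shown sits.

The compounds shown leave open which part of the 2-anilinoethyl chain carries this step, since the chain nitrogen and the added length enter together. As far as these compounds go, whether a longer chain, an ether oxygen in place of that nitrogen, or a substituent such as a methoxy group on the aniline ring would move the number further also remains open.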